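A few compounds are considered here, and "the series" means these few. Any claim that something is new, unique, unknown or untested is made for them only; others in the source may bear on it.

Measured compounds in this series:

Compound 1 `COc1ccc(-c2cnc(NC(=O)c3ccco3)n2C)cc1` gives > 100000 nM in a toxicity assay on THP-1 cells (Homo sapiens) for inhibition (a lower number here means that less compound is tolerated, a higher number that more compound is tolerated), a limit of the assay and not a number.
Compound 2 `COc1ccc(-c2cnc(NC(=O)c3ccccc3)n2C)cc1` gives > 100000 nM, likewise a limit.
Compound 3 `COc1ccc(-c2cnc(NC(=O)C3CCNCC3)n2C)cc1` gives > 100000 nM, again a limit.

Compound 3 therefore stands where the two other measured compounds stand: at the limit, with no readable number of its own. The three steps among the measured compounds, a step that the two limits leave unreadable from compound 1 to compound 2, a step that the two limits leave unreadable from compound 1 to compound 3 and a step that the two limits leave unreadable from compound 2 to compound 3, are all hidden by the limits on both sides, so none of them gives a size.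

Compound 4 `COc1ccc(-c2cnc(NC(=O)c3ccc(C#N)cc3)n2C)cc1` is not yet measured. It differs from compound 3 in one place: 4-cyanophenyl in place of piperidin-4-yl on a carbonyl carbon. The measured steps that bear on this change are the exchanges of the acyl group in compound 1, compound 2 and compound 3, and all of them are unreadable. For the measured compounds named here, the only evidence available is the limit of > 100000 nM in this assay, at which 3 of the 3 values shown sit.

Compound 4 is expected to sit at the same limit because the limit of > 100000 nM in this assay, at which 3 of the 3 values shown sit, holds for every acyl variant measured so far. The expected step is a step that the limit leaves unreadable from compound 3 to compound 4, meaning no readable change. The estimate for compound 4 is 150000 nM, with a range from 50000 nM to 500000 nM.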

Compound 4, half-maximal cytotoxic concentration: > 100000 nM
Compound 4: no number, only a limit (the forecaster's own chance of this, stated with the estimate: 85%); the middle value lies beyond the limit too.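

In this assay compound 4 gives > 100000 nM, a limit of the assay and not a number, so its steps from compound 1, compound 2 and compound 3 cannot be read. The compounds shown leave open whether any acyl group on this core gives a readable half-maximal cytotoxic concentration, and how these acyl groups rank.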